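The source may report more compounds than this note shows. Statements on the series, on what has been measured and on what is new or still open speak of the compounds shown alone.

Measured so far in a functional assay on BT-549 cells (Homo sapiens) for cytotoxicity, read by sulforhodamine B assay, with a stated time of 48 h, tested at 100 uM; on this read-out higher numbers stand for a weaker effect at the one concentration tested and lower numbers for a stronger effect:

- compound 1, `COc1cc(-c2cc(/C=C/C(=O)c3ccc(N)cc3)[nH]n2)cc(OC)c1OC`: -97%
- compound 2, `COc1ccc(-c2cc(/C=C/C(=O)c3ccc(OC)c(OC)c3)[nH]n2)cc1`: -99%
- compound 3, `COc1ccc(-c2cc(/C=C/C(=O)c3ccc(N)cc3)[nH]n2)cc1`: -61%

On these three numbers compound 1 stands second highest. Its nearest neighbour is compound 2, whose number lies within the scatter of it, so the two cannot be told apart. Compound 3 lies furthest away, a number beyond the scatter and well higher, meaning a weaker effect.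

Compound 4, `COc1ccc(C(=O)/C=C/c2cc(-c3cc(OC)c(OC)c(OC)c3)n[nH]2)cc1OC`, has not yet been measured. It differs from compound 1 in one place: 3,4-dimethoxyphenyl in place of 4-aminophenyl on a carbonyl carbon. Going by the values given here, with no measured step of this kind to lean on, the expectation rests on compound 2, whose number -99% with the same entering group is as low as that of compound 1. Compound 4 is therefore expected to give -97%, in the range -100% to -85%, a step of no change at the digits printed from compound 1 to compound 4 (within the scatter) that is expected to stay within the scatter.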

Compound 4, a percentage reported as activity, at one concentration (the size of the read-out at that concentration, not a potency): -75%
For compound 4 the middle estimate is 22 percentage points below the measured one; the whole stated range lies below it.
By their numbers in this assay, from the lowest: compounds 2 and 1 (each within the scatter of the next); then compound 4; then compound 3.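

Putting 3,4-dimethoxyphenyl in place of 4-aminophenyl on a carbonyl carbon gives a number 22 percentage points higher from compound 1 to compound 4 (beyond the scatter) in this assay, a weaker effect, so the group at this position matters for compound 1. The same two groups separate compound 3 at -61% from compound 2 at -99%, but there 3,4-dimethoxyphenyl carries the lower number, so the change does not read the same way on both backgrounds. Nothing available explains this difference.

As far as these compounds go, it remains open how a plain phenyl or a 4-hydroxyphenyl would read at this position, and on which background.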